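The compounds below may be only part of what the source reports. "The series", "measured", "known", "first", "only" and "open" are said of these compounds alone.

Three measured compounds share one core and differ only in the group that hangs from the five-membered aromatic ring. Compound 1 `CCC(CC)N(CCN(C)C(=O)CCC(=O)O)Cc1cccc(C(=O)Nc2sc3c(c2C(=O)c2cnn(-c4ccc(Cl)c(C(F)(F)F)c4)c2)CCC(C)(C)C3)c1` gives 38 nM in an assay on isolated protein for inhibition of sodium-dependent phosphate transport protein 2B (Homo sapiens) (a higher number here means a weaker inhibitor, a lower number a stronger inhibitor), the lowest number of the three. Compound 3 `CCC(CC)N(CCN(C)C(=O)CCC(=O)O)Cc1cccc(C(=O)Nc2sc3c(c2C(=O)c2cnn(-c4ccc(Cl)cc4)c2)CCN(C2CC2)C3)c1` gives 80 nM in this assay, and compound 2 `CCC(CC)N(CCN(C)C(=O)CCC(=O)O)Cc1cccc(C(=O)Nc2sc3c(c2C(=O)c2cnn(-c4ccc(Cl)cc4)c2)CCSC3)c1` gives 713 nM there; both steps from compound 1 lie beyond the usual scatter, so compound 1 is the strongest inhibitor among them.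

Compound 4 `CCC(CC)N(CCN(C)C(=O)CCC(=O)O)Cc1cccc(C(=O)Nc2sc3c(c2C(=O)c2cnn(Cc4ccc(C(=O)O)cc4)c2)CCC(C)(C)C3)c1` carries one change relative to compound 1: 4-carboxybenzyl in place of 4-chloro-3-(trifluoromethyl)phenyl on an aromatic nitrogen. For the measured compounds named here, no measured pair shows this exact change, so there is no direct precedent. A step of this kind is nevertheless expected to weaken inhibition, and the step from compound 1 to compound 4 is estimated at a 7.9-fold higher number from compound 1 to compound 4 (0.90 log units; beyond the scatter). Compound 4 is thus expected to give about 300 nM, within 60 nM to 2000 nM.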

Compound 4, half-maximal inhibitory concentration: > 1000 nM
Compound 4 ended at the assay's limit; the forecaster's own chance of this, stated with the estimate: 10%; middle value at least 3.3-fold (0.52 log units) away from the limit.
By their numbers in this assay, from the lowest: compound 1; then compound 3; then compound 2. At a limit, above all of these: compound 4.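

For the compounds shown here, the group on this aromatic nitrogen turns out to matter a great deal: all the earlier compounds carry a chlorine-bearing phenyl group here, and 4-carboxybenzyl in its place gives an at least 26-fold higher number from compound 1 to compound 4 (1.42 log units; beyond the scatter) in this assay. Compound 4 stands at a limit of the assay, not at a true number: the limit of > 1000 nM in this assay, at which 1 of the 4 values shown sits.

The compounds shown cannot separate the carboxylic acid from the benzyl link, since both enter together. A plain benzyl or a 4-carboxyphenyl group on this nitrogen would be needed to tell these two apart.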